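A few compounds are considered here, and "the series" means these few. Any claim that something is new, unique, unknown or untested is made for them only; others in the source may bear on it.

Measured so far:
- compound 1 `Cn1c([N+](=O)[O-])cnc1C(=O)NCc1ccccn1`: > 100000 nM
- compound 2 `CN(C)C(=O)c1ncc([N+](=O)[O-])n1C`: > 100000 nM
- compound 3 `O=C(NCc1ccccn1)c1ncc([N+](=O)[O-])[nH]1`: > 100000 nM

In a toxicity assay on HEK293 cells (Homo sapiens) for inhibition, read by resazurin assay, with a stated time of 24 h (a lower number here means that less compound is tolerated, a higher number that more compound is tolerated), compound 1 gives > 100000 nM, which is a limit of the assay and not a number. Compound 2 gives > 100000 nM in this assay, again a limit. Compound 3 gives > 100000 nM, also a limit. All three values sit at the limit of > 100000 nM in this assay, at which 3 of the 3 values shown sit.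

Compound 1 and compound 3 differ by hydrogen in place of methyl on an aromatic nitrogen. The step that the two limits leave unreadable from compound 1 to compound 3 follows, and its size cannot be read because both values are limits. The difference between the core of compound 1 and the core of compound 2 is not broken down here.

Compound 4 `CN(C)C(=O)c1ncc([N+](=O)[O-])[nH]1` is not yet measured. It differs from compound 2 by hydrogen in place of methyl on an aromatic nitrogen. This is the same kind of change as from compound 1 to compound 3; around the place the ring atom in compound 2 bears a group of 5 heavy atoms, whereas in compound 1 it bears a large group.

For compound 4 a step that the limit leaves unreadable from compound 2 to compound 4 is expected, resting on compound 2 at > 100000 nM and on the unreadable step from compound 1 to compound 3, so it is estimated that compound 4 again sits at the limit. The estimate for compound 4 is 150000 nM.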

Compound 4, half-maximal cytotoxic concentration: > 100000 nM
Compound 4 gave a limit, no number (the forecaster's own chance of this, stated with the estimate: 85%); the middle value lies beyond the limit too.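

In this assay no new step can be read between compound 2 and compound 4, as both values are limits of the assay and not numbers: the limit of > 100000 nM in this assay, at which 4 of the 4 values shown sit.

The compounds shown leave open at what concentration any of them becomes toxic, and whether hydrogen in place of methyl on the aromatic nitrogen alters tolerance at all.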